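Swapping the Anilino Ring in a Cytotoxicity Series

The compounds below may be only part of what the source reports. "The series", "measured", "known", "first", "only" and "open" are said of these compounds alone.

Measured so far:
compound 1, `Fc1cccc(-c2nc(Nc3ccccc3F)c3cc(F)ccc3n2)c1`, > 50000 nM
compound 2, `Fc1cccc(-c2nc(Nc3ccccc3Cl)c3cc(F)ccc3n2)c1`, > 50000 nM

In a functional assay on MDA-MB-231 cells (Homo sapiens) for cytotoxicity, read by MTT assay, with a stated time of 48 h (on this read-out higher numbers stand for weaker inhibition and lower numbers for stronger inhibition), compound 1 gives > 50000 nM, which is a limit of the assay rather than a number. Compound 2 likewise gives > 50000 nM in this assay, again a limit. Among the measured compounds shown here, the only step between measured compounds, a step that the two limits leave unreadable from compound 1 to compound 2, therefore cannot be read, and both values sit at the limit of > 50000 nM in this assay, at which 2 of the 2 values shown sit.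

Compound 3, `Cc1cccc(Nc2nc(-c3cccc(F)c3)nc3ccc(F)cc23)c1`, is not yet measured. It differs from compound 2 by 3-methylphenyl in place of 2-chlorophenyl on a nitrogen on an aromatic ring. For the measured compounds named here, no measured step bears on this change, so nothing points to a shift in either direction in this assay; what the shared core does with any anilino ring so far is simply beyond the reach of the assay.

Compound 3 is expected to follow compound 2, with an estimated step of a number no higher from compound 2 to compound 3 (the limit leaves the size open). For compound 3 the estimate in this assay is 50000 nM, between 10000 nM and 200000 nM, most likely reported only as a limit.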

Compound 3, half-maximal inhibitory concentration: > 50000 nM
Compound 3 was reported as a limit; the forecaster's own chance of this, stated with the estimate: 70%; the middle value sits exactly at the limit.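

In this assay compound 3 gives > 50000 nM, again a limit rather than a number. Its steps from compound 1 and compound 2 therefore cannot be read: the limit of > 50000 nM in this assay, at which 3 of the 3 values shown sit.

The compounds shown leave open whether these three differ at all, and which change would give a readable number.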